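Benzyl in Place of a Halogenated Phenyl on a Urea

The compounds below may be only part of what the source reports. "The series", "measured", "known", "first", "only" and "open" are said of these compounds alone.

Three measured compounds share one readout, a functional assay on HepG2 cells (Homo sapiens) for antiproliferative activity, with a stated time of 72 h; a lower number here means that less compound is needed, a higher number that more compound is needed for the effect. Compound 1 `COc1ccc(-c2c(Cl)c(=O)c3c(OC)cc(OC)cc3n2S(=O)(=O)c2ccc(OC)cc2)cc1` has no result in this assay, recorded as "not determined" (no result reported). Compound 2 `COc1ccc(-c2cc(=O)c3c(OC)cc(OC)cc3n2S(=O)(=O)c2c(C(C)C)cc(C(C)C)cc2C(C)C)cc1` reaches only a limit of the assay rather than a number, > 341000 nM. Compound 3 `COC(=O)c1cc(=O)c2cc(NC(=O)Nc3ccc(F)c(Cl)c3)ccc2[nH]1` also stops at a limit of the assay, > 6350 nM. Compound 3 therefore stands nowhere definite on the numbers: its own value is a limit, one further value is a limit, and one further entry carries no single number at all. Among the measured compounds shown here, no step between two measured compounds is available here.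

Compound 4 `COC(=O)c1cc(=O)c2cc(NC(=O)NCc3ccccc3)ccc2[nH]1` differs from compound 3 by benzyl in place of 3-chloro-4-fluorophenyl on an amide-type nitrogen. With nothing measured to lean on, no step beyond the usual scatter is expected in either direction, and the expected step from compound 3 to compound 4 is a step that the limit leaves unreadable from compound 3 to compound 4. Compound 4 is accordingly estimated at 15000 nM, within a range from 5000 nM to 60000 nM.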

Compound 4, half-maximal effective concentration: > 19500 nM
Compound 4 was reported as a limit; the forecaster's own chance of this, stated with the estimate: 75%; middle value at least 1.3-fold (0.11 log units) from the limit.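

Among the compounds shown here, compound 3 and compound 4 both stop at a limit in this assay, so no step between them can be read. The compounds shown leave open whether benzyl in place of 3-chloro-4-fluorophenyl on the urea changes the concentration needed for the effect, and in which direction.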